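Three Hydrazones at the Cytotoxicity Limit, and a Fourth

A few compounds are considered here, and "the series" means these few. Any claim that something is new, unique, unknown or untested is made for them only; others in the source may bear on it.

Compound 1 is `Cc1ccc(/C=N/N(C(=O)c2ccccc2)C(=O)c2ccncc2)cc1`. In an ADME assay on HEL cells (Homo sapiens) for cytotoxicity (on this read-out lower numbers stand for higher toxicity in this test and higher numbers for lower toxicity in this test), compound 1 gives > 100 ug/mL, which is a limit of the test and not a number.
Compound 2 is `O=C(N/N=C/c1c[nH]c2ccccc12)c1ccncc1`. In this assay compound 2 gives > 100 ug/mL, again a limit rather than a number.
Compound 3 is `COc1cccc(OC)c1/C=N/NC(=O)c1ccncc1`. In this assay compound 3 gives > 100 ug/mL, also a limit.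

All three measured compounds thus stand at the same place: the limit of > 100 ug/mL in this assay, at which 3 of the 3 values shown sit. Compound 1 stands neither higher nor lower than compound 2 or compound 3; the three share one limit, and no order among them can be read from these data. Within the data shown here, no pair of them differs in only one place, so no measured step between them exists.

Compound 4 is `COc1cc(/C=N/N(C(=O)c2ccccc2)C(=O)c2ccncc2)ccc1O`. It differs from compound 1 in one place: 4-hydroxy-3-methoxyphenyl in place of 4-methylphenyl on a carbon with a double bond to nitrogen. The shared core of compound 1, with its two carbonyl groups, stays untouched.

Because compound 1 sits at the limit of > 100 ug/mL in this assay, at which 3 of the 3 values shown sit, and compound 2 and compound 3 with quite different aryl groups sit there as well, the step from compound 1 to compound 4 is expected to be a number no higher from compound 1 to compound 4 (the limit leaves the size open), that is, no change beyond the scatter in either direction. Compound 4 is estimated at 100 ug/mL, within a range from 50 ug/mL to 200 ug/mL, and the test will most likely again report only its limit.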

Compound 4, minimum cytotoxic concentration: > 100 ug/mL
Compound 4: no number, only a limit; the forecaster's own chance of this, stated with the estimate: 80%; the middle value lies on the limit itself.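

The step between compound 1 and compound 4 cannot be read in this assay, as each gives only a limit of the test and not a number: the limit of > 100 ug/mL in this assay, at which 4 of the 4 values shown sit.

The compounds shown leave open at what concentration, if any, each would harm these cells, and whether 4-hydroxy-3-methoxyphenyl and 4-methylphenyl differ at all on this read-out.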